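The compounds below may be only part of what the source reports. "The series", "measured", "known", "first", "only" and "open" are said of these compounds alone.

Compound 1 `CONC(=O)c1sc(-c2ccc(Cl)cc2)nc1C(Br)Br` gives 81400 nM in an ADME assay on BHK15 cells (Mesocricetus auratus) for inhibition, read by XTT assay, with a stated time of 36 h (a lower number here means a stronger inhibitor of growth, a higher number a weaker inhibitor of growth), the highest of the two numbers in hand. Compound 2 `C#CCNC(=O)c1sc(-c2ccc(Cl)cc2)nc1C(Br)Br` gives 23900 nM, and the step of a 3.4-fold lower number from compound 1 to compound 2 (0.53 log units; beyond the scatter) was beyond the scatter. Compound 3 `CC(C)OC(=O)c1sc(-c2ccc(Cl)cc2)nc1C(Br)Br` differs from compound 1 at the carbonyl carbon: isopropoxy in place of methoxyamino on a carbonyl carbon. Going by the values given here, that measured step changed the substituent on the amide-type nitrogen, not the methoxyamino group itself, so it bears only loosely on this change; the one precedent points to a modest lowering. A modest step, a 1.8-fold lower number from compound 1 to compound 3 (0.26 log units; within the scatter), is therefore expected, giving compound 3 an estimated 45000 nM with a range from 12000 nM to 150000 nM.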

Compound 3, concentration for 50% growth inhibition: 372000 nM
Compound 3: the middle estimate sits 8.3-fold (0.92 log units) below what was measured; the whole stated range lies below it.
By their numbers in this assay, from the lowest: compound 2; then compound 1; then compound 3.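

Nitrogen-linked and oxygen-linked groups on this carbonyl carbon are not interchangeable: isopropoxy in place of methoxyamino gives a 4.6-fold higher number from compound 1 to compound 3 (0.66 log units; beyond the scatter) and isopropoxy in place of propargylamino gives a 16-fold higher number from compound 2 to compound 3 (1.19 log units; beyond the scatter). Among these compounds, both groups with a hydrogen-bond donor on the nitrogen give lower numbers than isopropoxy, with none going against this, though the change of linking atom and the change of chain are not separated here. No measured evidence accounts for this difference.

Going by these compounds, it remains open whether methoxy on the carbonyl carbon would match isopropoxy, which would separate the linking atom from the chain. A carboxylic acid or a tertiary amide in this place also remains untested within the compounds shown.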